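Anilinoquinazoline thioacetamides: halogen pattern on the anilino ring

This account rests on a few compounds, and the source may have more. Where it says the series, first, only, none or still open, it means among the compounds named here.

Measured in a functional assay on MDA-MB-231 cells (Homo sapiens) for inhibition, read by MTT assay, with a stated time of 72 h; on this read-out higher numbers stand for weaker inhibition and lower numbers for stronger inhibition:
- compound 1 `C=CC(=O)Nc1cccc(NC(=O)CSc2nc(Nc3cccc(Br)c3)c3ccccc3n2)c1`: 19400 nM
- compound 2 `C=CC(=O)Nc1cccc(NC(=O)CSc2nc(Nc3cccc(C)c3)c3ccccc3n2)c1`: 16800 nM
- compound 3 `C=CC(=O)Nc1cccc(NC(=O)CSc2nc(Nc3ccc(Br)cc3)c3ccccc3n2)c1`: 17300 nM

All three values lie within the scatter of one another. Compound 3 stands close to both others: a 1.0-fold higher number from compound 2 to compound 3 (0.01 log units; within the scatter) and a 1.1-fold lower number from compound 1 to compound 3 (0.05 log units; within the scatter). Compound 4 `C=CC(=O)Nc1cccc(NC(=O)CSc2nc(Nc3ccc(Cl)cc3Cl)c3ccccc3n2)c1` is the next member, with 2,4-dichlorophenyl in place of 4-bromophenyl on a nitrogen on an aromatic ring. Within the data shown here, the steps that bear on it are those in which the group on this nitrogen was varied: a 1.1-fold lower number from compound 1 to compound 3 (0.05 log units; within the scatter), a 1.2-fold lower number from compound 1 to compound 2 (0.06 log units; within the scatter) and a 1.0-fold higher number from compound 2 to compound 3 (0.01 log units; within the scatter), none of them beyond the scatter. Moving or exchanging a halogen on this ring has so far left this assay unchanged, so no step beyond the scatter is expected here either. For compound 4 the expected value is 17000 nM (range 8000 nM to 36000 nM), an expected step of a 1.0-fold lower number from compound 3 to compound 4 (0.01 log units; within the scatter).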

Compound 4, half-maximal inhibitory concentration: 23100 nM
For compound 4 the middle estimate is 1.4-fold (0.13 log units) below the measured one; the measured number falls inside the stated range.
By their numbers in this assay, from the lowest: compounds 2, 3, 1 and 4 (each within the scatter of the next).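

In this assay the 2,4-dichlorophenyl group, the first ring in the set with two halogens, stays level with the rings carrying one substituent: a 1.3-fold higher number from compound 3 to compound 4 (0.13 log units; within the scatter), a 1.4-fold higher number from compound 2 to compound 4 (0.14 log units; within the scatter) and a 1.2-fold higher number from compound 1 to compound 4 (0.08 log units; within the scatter). On this nitrogen, a second halogen therefore gives no step beyond the scatter, just as moving or exchanging one substituent did not. No measurement is available that would explain these values. The compounds shown leave open whether an amine, a carboxylic acid or a longer chain on this ring would give a step beyond the scatter.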